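Swapping the anilino aryl on a shared core

The compounds below may be only part of what the source reports. "The series", "measured", "known", "first", "only" and "open" are said of these compounds alone.

Going by the values given here, compound 1 `N#Cc1c(Nc2cccc(C(F)(F)F)c2)nc(SCc2cn(Cc3ccccc3Cl)nn2)nc1-c1ccccc1` gives 12600 nM in a functional assay on MCF7 cells (Homo sapiens) for inhibition, read by MTT assay, with a stated time of 72 h (a higher number here means a weaker inhibitor, a lower number a stronger inhibitor), the only plain number among the two values shown. Compound 2 `N#Cc1c(Nc2cccc([N+](=O)[O-])c2)nc(SCc2cn(Cc3ccccc3Cl)nn2)nc1-c1ccccc1` reaches only the assay limit of > 64000 nM in this assay. The step from compound 1 to compound 2 was an at least 5.0-fold higher number from compound 1 to compound 2 (0.70 log units; beyond the scatter), with one of the two values at the limit of > 64000 nM in this assay, at which 1 of the 2 values shown sits. Compound 3 `Cc1ccccc1Nc1nc(SCc2cn(Cc3ccccc3Cl)nn2)nc(-c2ccccc2)c1C#N` differs from compound 1 by 2-methylphenyl in place of 3-(trifluoromethyl)phenyl on a nitrogen on an aromatic ring. Among the compounds with values here, the only measured step alters the same ring but exchanges a different group, so it offers weak guidance. A modest weakening is expected, a 1.7-fold higher number from compound 1 to compound 3 (0.24 log units; within the scatter). Compound 3 is therefore estimated at 22000 nM, between 7000 nM and 64000 nM.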

Compound 3, half-maximal inhibitory concentration: 7950 nM
Compound 3: the middle estimate sits 2.8-fold (0.44 log units) above what was measured; low and high end bracket the measured number.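

Exchanging 3-(trifluoromethyl)phenyl for 2-methylphenyl on the nitrogen gives a 1.6-fold lower number from compound 1 to compound 3 (0.20 log units; within the scatter), so in this assay these two aryl groups cannot be told apart. Replacing 3-nitrophenyl with 2-methylphenyl gives an at least 8.0-fold lower number from compound 2 to compound 3 (0.90 log units; beyond the scatter), which sets 3-nitrophenyl apart from both other aryl groups. Compound 2 stands at a limit of the assay, not at a number: the limit of > 64000 nM in this assay, at which 1 of the 3 values shown sits.

The compounds shown leave open whether an amine or a carboxylic acid on this ring would track 3-nitrophenyl or the other two groups. They also cannot separate the group's identity from its place on the ring, since methyl and trifluoromethyl differ in both.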